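The source may report more compounds than this note shows. Statements on the series, on what has been measured and on what is new or still open speak of the compounds shown alone.

In an assay on membranes from brain for binding affinity to Neuronal acetylcholine receptor; alpha4/beta2 (Rattus norvegicus) (on this read-out higher numbers stand for weaker inhibition and lower numbers for stronger inhibition), compound 1 `Cc1ccc(-c2cncc(OC[C@@H]3CCCN3C)c2)cc1` gives 0.13 nM. Compound 2 `CN1CCC[C@H]1COc1cncc(-c2ccco2)c1` keeps the same core with a different aryl group, and in this assay compound 2 gives 0.19 nM. Among the measured compounds shown here, the one step measured so far, a 1.5-fold higher number from compound 1 to compound 2 (0.16 log units; within the scatter), shows that exchanging this aryl group left the number within the scatter. Among the two numbers shown, compound 2 stands highest, with compound 1 as its nearest neighbour at a gap that is within the scatter. Compound 3 `CN1CCC[C@H]1COc1cncc(-c2cncnc2)c1` differs from compound 2 by pyrimidin-5-yl in place of furan-2-yl on an aromatic carbon. For the measured compounds named here, the only measured step that bears on such an aryl exchange was within the scatter, so no step beyond the scatter in this assay is expected for this change either, although a small shift toward a higher number cannot be ruled out. Compound 3 is therefore expected to give 0.3 nM, within a range from 0.08 nM to 1.5 nM. This expectation corresponds to a 1.6-fold higher number from compound 2 to compound 3 (0.20 log units; within the scatter).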

Compound 3, inhibition constant: 0.37 nM
For compound 3 the middle estimate is 1.2-fold (0.09 log units) below the measured one; the range from low to high includes it.
By their numbers in this assay, from the lowest: compounds 1, 2 and 3 (each within the scatter of the next, the first and the last beyond it).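

In this assay, pyrimidin-5-yl in place of furan-2-yl on this aromatic carbon, two atoms from the ring nitrogen, stays within the scatter (a 1.9-fold higher number from compound 2 to compound 3 (0.29 log units; within the scatter)), so a six-membered aromatic ring with 2 hetero atoms is accommodated here as readily as the five-membered one. The same position now also yields its first step beyond the scatter, though a modest one, with pyrimidin-5-yl in place of 4-methylphenyl (a 2.8-fold higher number from compound 1 to compound 3 (0.45 log units; beyond the scatter)), showing that the choice of aryl group is not entirely without consequence. Nothing available explains this step.

The compounds shown carry only aromatic rings at this position, so it remains open how an amine, a carboxylic acid or a longer chain would fare there. From the compounds shown here alone, whether a phenyl ring without the methyl group would match compound 1 also remains open.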